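Fluoro for phenyl: no large step expected

The source may hold more compounds than are shown below. What is called first, only, known or untested is meant among the compounds shown, and "the series" means these compounds.

In a functional assay on MGC-803 cells (Homo sapiens) for inhibition, read by MTT assay, with a stated time of 72 h (on this read-out lower numbers stand for stronger inhibition and higher numbers for weaker inhibition), compound 2 (`O=C(NCc1ccc(NC(=O)c2cc(-c3ccccc3)ccc2N2CCCC2)cc1)OCc1cccnc1`) gives 10500 nM. Going by the values given here, its only measured neighbour, compound 1 (`Cc1ccc(N2CCCC2)c(C(=O)Nc2ccc(CNC(=O)OCc3cccnc3)cc2)c1`), gives 19100 nM, and these two values lie within the scatter of each other, so they cannot be ranked.

Compound 3 (`O=C(NCc1ccc(NC(=O)c2cc(F)ccc2N2CCCC2)cc1)OCc1cccnc1`) differs from compound 2 in one place: fluoro in place of phenyl on an aromatic carbon. This is fluoro in place of phenyl on an aromatic carbon, para to a pyrrolidin-1-yl group.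

Among the compounds with values here, one measured step bears on this change, phenyl in place of methyl on that same aromatic carbon: a 1.8-fold lower number from compound 1 to compound 2 (0.26 log units; within the scatter). It is small, and neither measured compound carries fluoro, so the evidence is thin. On that basis, the expected step is a 1.4-fold higher number from compound 2 to compound 3 (0.15 log units; within the scatter), with nothing beyond the scatter foreseen. For compound 3 the estimated value is 15000 nM, with an expected range of 6000 nM to 38000 nM.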

Compound 3, half-maximal inhibitory concentration: 10700 nM
For compound 3 the middle estimate is 1.4-fold (0.15 log units) above the measured one; measured number inside the range.
By their numbers in this assay, from the lowest: compounds 2, 3 and 1 (each within the scatter of the next).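

In this assay the change from phenyl to fluoro gives a 1.0-fold higher number from compound 2 to compound 3 (0.01 log units; within the scatter) and the change from methyl to fluoro gives a 1.8-fold lower number from compound 1 to compound 3 (0.25 log units; within the scatter) on the same aromatic carbon, para to a pyrrolidin-1-yl group. With compound 3 in hand, this position has now carried three different groups, from a single fluorine atom to a six-carbon aromatic ring, and the three compounds still cannot be ranked. Nothing available explains why the number stays within the scatter across these groups.

On these data alone, whether an amine, a carboxylic acid or a longer chain on this carbon would move the number beyond the scatter remains open. Also open, as far as these compounds go, is whether any group here can bring the number far below those of these three compounds, or whether changes elsewhere on the shared core matter more.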